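Swapping Chloro for Fluoro in a Nearly Silent Series

A few compounds are considered here, and "the series" means these few. Any claim that something is new, unique, unknown or untested is made for them only; others in the source may bear on it.

In a functional assay on NCI-H460 cells (Homo sapiens) for inhibition, read by MTT assay, with a stated time of 24 h, tested at 0.1 ug/mL (a lower number here means less inhibition of growth, a higher number more inhibition of growth at the concentration tested), compound 1 (`O=C(CCCCC1CCSS1)Nc1ccccn1`) gives 2.61% and compound 2 (`O=C(CCCCC(S)CCS)Nc1ccccc1`) gives 5.5% as its reading, so these two sit within normal scatter of each other and both readings are small. Compound 3 (`O=C(CCCCC(S)CCS)Nc1ccc(Cl)cc1`) is reported as "not active" (no number reported) with no figure attached, which means it has no exact place on the scale and cannot be ranked precisely against the other two.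

The next structure, compound 4 (`O=C(CCCCC(S)CCS)Nc1ccc(F)cc1`), is a single swap of fluoro in place of chloro on an aromatic carbon. Counted group by group, the change runs fluoro in place of chloro on an aromatic carbon and the rest of the molecule stays the same.

Going by the values given here, no measured pair in this small set shows what such a swap does in this assay so there is no direct guide to its size. With compound 2 at 5.5% and compound 3 reported as "not active" (no number reported) the closest relatives both lie near the bottom of the scale, so no step beyond the scatter is expected in either direction. For compound 4 the estimated growth inhibition is 4% within an expected range of 0% to 15% and a report without any number would also fit.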

Compound 4, percent growth inhibition at one concentration: 5.64%
For compound 4 the middle estimate is 1.6 percentage points below the measured one; measured number inside the range.
By their numbers in this assay, from the lowest: compounds 1, 2 and 4 (each within the scatter of the next).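

In this assay, going by these compounds alone, replacing the hydrogen with a fluoro group, para to a large group, gives the only readable step at this position (a number 0.1 percentage points higher from compound 2 to compound 4 (within the scatter)), so on this shared core the fluoro compound cannot be told apart from the compound with hydrogen at that place. On these data alone, the swap of chloro for fluoro itself cannot be read: compound 3 gives "not active" (no number reported) with no number to set against compound 4, and so the size of that change remains unknown. Nothing on hand offers a measured reason for these small readings.

The compounds shown leave open whether any group at this place on the ring could move the reading beyond the scatter, for example an amine, a methoxy group or a carboxylic acid, since only hydrogen and fluoro give numbers to compare here. They also leave open what a longer chain between the carbonyl and the sulfur-bearing end of the molecule would do to growth inhibition on this core, at this one tested concentration.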